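A few compounds are considered here, and "the series" means these few. Any claim that something is new, unique, unknown or untested is made for them only; others in the source may bear on it.

Compound 3 `O=S(=O)(NCCCNCc1ccccc1)c1cc(C(F)(F)F)cc(C(F)(F)F)c1` carries an unsubstituted benzyl group on the amine nitrogen of the shared core, and in a functional assay on HT-29 cells (Homo sapiens) for inhibition, read by MTT assay, with a stated time of 72 h (on this read-out higher numbers stand for weaker inhibition of growth and lower numbers for stronger inhibition of growth), compound 3 gives 15000 nM, the highest of the three numbers measured. Its neighbours differ only on that benzyl carbon: compound 1 `COc1ccc(CNCCCNS(=O)(=O)c2cc(C(F)(F)F)cc(C(F)(F)F)c2)cc1OC` gives 2700 nM and compound 2 `O=S(=O)(NCCCNCC1COc2ccccc2O1)c1cc(C(F)(F)F)cc(C(F)(F)F)c1` gives 2200 nM. Both steps toward compound 3 are beyond the scatter: a 5.6-fold higher number from compound 1 to compound 3 (0.74 log units; beyond the scatter) and a 6.8-fold higher number from compound 2 to compound 3 (0.83 log units; beyond the scatter), while the two substituted analogues themselves lie within the scatter of each other, a 1.2-fold lower number from compound 1 to compound 2 (0.09 log units; within the scatter).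

Compound 4 `O=S(=O)(NCCCNCc1cccc(Cl)c1)c1cc(C(F)(F)F)cc(C(F)(F)F)c1` is reached from compound 3 by chloro in place of hydrogen on an aromatic carbon, so that the benzyl becomes a 3-chlorobenzyl. Among the compounds with values here, no measured step adds a chloro, but the two steps that strip the ring of substituents both raised the number, so compound 4 is expected to move in the opposite direction, though more cautiously than those steps, and its estimate in this assay is 6000 nM, ranging from 2000 nM to 18000 nM. The step expected from compound 3 to compound 4 is therefore a 2.5-fold lower number from compound 3 to compound 4 (0.40 log units; beyond the scatter).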

Compound 4, concentration for 50% growth inhibition: 14000 nM
Beside the measured number, compound 4's estimate is 2.3-fold (0.37 log units) below it; measured number inside the range.
By their numbers in this assay, from the lowest: compounds 2 and 1 (each within the scatter of the next); then compounds 4 and 3 (each within the scatter of the next).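

In this assay the chloro on an aromatic carbon, meta to a large group, gives no separable difference: a 1.1-fold lower number from compound 3 to compound 4 (0.03 log units; within the scatter). The lower numbers of the two substituted analogues therefore do not follow from just any substituent on the benzyl ring, since a clear gap remains, with a 6.4-fold higher number from compound 2 to compound 4 (0.80 log units; beyond the scatter) and a 5.2-fold higher number from compound 1 to compound 4 (0.71 log units; beyond the scatter), so 3-chlorophenyl stays apart from both 2,3-dihydro-1,4-benzodioxin-2-yl and 3,4-dimethoxyphenyl. No measurement at hand accounts for this difference between the groups.

From the compounds shown here alone, whether one methoxy group or a hydroxy group on the same aromatic carbon would bring the number towards that of compound 1 remains open. So does whether a chloro on another carbon of the ring would behave as it does in compound 4.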